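The compounds below may be only part of what the source reports. "The series", "measured", "known", "first", "only" and "open" are said of these compounds alone.

In a functional assay on BGC-823 cells (Homo sapiens) for inhibition, read by sulforhodamine B assay, with a stated time of 48 h, tested at 10 uM (on this read-out higher numbers stand for more inhibition of growth at the one concentration tested and lower numbers for less inhibition of growth), three compounds have been measured so far. Compound 1 `O=C(N/N=C/c1ccc(Cl)cc1)c1ccc(-c2ccccc2F)o1` gives 32.6% and compound 3 `O=C(N/N=C/c1ccc(-c2ccccc2F)o1)c1ccc(Cl)cc1` gives 31.5%; these two numbers lie within the usual scatter of each other. Compound 2 `O=C(N/N=C/c1ccc(-c2ccc(F)cc2F)o1)c1ccccc1O` gives 68.4%, the highest of the three, and its lead over compound 1 and over compound 3 is beyond the scatter. Compound 2 thus stands clearly apart from the other two measured compounds on this read-out.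

Compound 4 `COc1ccccc1C(=O)N/N=C/c1ccc(-c2ccc(F)cc2F)o1` has not yet been measured. It differs from compound 2 in one place: methyl in place of hydrogen on an oxygen on an aromatic ring. For the measured compounds named here, no pair of measured compounds shows this change, so there is no measured step to lean on; the expectation rests only on the structural change itself, which is small in count. A change of this kind could leave the number roughly where it is or move it in either direction, and the more cautious expectation is a moderate fall from the high number of compound 2, with wide uncertainty. The step of a number 18.4 percentage points lower from compound 2 to compound 4 (beyond the scatter) is estimated to be a decrease somewhat beyond the scatter. Compound 4 is therefore expected to give about 50%, with a likely range from 25% to 75%.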

Compound 4, percent growth inhibition at one concentration: 35.9%
Beside the measured number, compound 4's estimate is 14.1 percentage points above it; low and high end bracket the measured number.
By their numbers in this assay, from the lowest: compounds 3, 1 and 4 (each within the scatter of the next); then compound 2.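

In this assay the change from hydroxy to methoxy, which puts methyl in place of hydrogen on an oxygen on an aromatic ring, gives a number 32.5 percentage points lower from compound 2 to compound 4 (beyond the scatter) and so counts as a large step for the addition of a single carbon. For the compounds shown here, this is the first pair in the set that differs in one place, so it is the first direct sign that the number at this position depends on what sits on this oxygen, and that the high value of compound 2 does not survive this small edit. Nothing measured here accounts for the size of the fall, so the step stands as an observation without an explanation.

Going by these compounds, it remains open whether the loss is specific to methyl or would follow any replacement of that hydrogen, which an ethyl group, a longer chain or an amine in place of the hydroxy group could help to settle. On these data alone, it also remains open whether the same change from 2-hydroxyphenyl to 2-methoxyphenyl would cost as much if another part of the molecule were different.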